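Leukotriene C4 synthase inhibitors: isobutyl to propyl step

The source may hold more compounds than are shown below. What is called first, only, known or untested is meant among the compounds shown, and "the series" means these compounds.

Measured compounds:
compound 1 `COc1nc(C(=O)[C@@H]2C[C@H]2C(=O)O)ncc1N(CC1CC1)c1ccc(Cl)c2ccccc12` — 15.5 nM
compound 2 `COc1cc(N(CC(C)C)c2cccc(C(F)(F)F)c2)cnc1C(=O)[C@H]1C[C@@H]1C(=O)O` — 4.74 nM

In an assay for inhibition of leukotriene C4 synthase (Homo sapiens), read by LC-MS, with stated times of 15 min and 30 min (on this read-out lower numbers stand for stronger inhibition and higher numbers for weaker inhibition), compound 2 gives the lower of the two numbers shown. The nearest measured compound is compound 1, whose number in this assay stands higher, and that gap lies beyond the usual scatter. Compound 3 `CCCN(c1cccc(C(F)(F)F)c1)c1cnc(C(=O)[C@H]2C[C@@H]2C(=O)O)c(OC)c1` is the next compound of the series and is still to be measured. It differs from compound 2 in one place: hydrogen in place of methyl on a saturated chain carbon bound to two saturated chain carbons, that is, isopropyl to ethyl or, seen from the next bond, isobutyl to propyl. Among the compounds with values here, no measured pair shows this change, so its size is not known from the data. The change removes one carbon from the chain on the nitrogen and leaves the rest of compound 2 untouched, so no step beyond the scatter is expected, at most a slight drift toward a higher number. The expected step in this assay from compound 2 to compound 3 is a 1.4-fold higher number from compound 2 to compound 3 (0.14 log units; within the scatter). Compound 3 is therefore expected to give about 6.5 nM in this assay, with a range from 2.5 nM to 17 nM.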

Compound 3, half-maximal inhibitory concentration: 7.9 nM
Compound 3: the middle estimate sits 1.2-fold (0.08 log units) below what was measured, and the stated range covers the measured number.
By their numbers in this assay, from the lowest: compounds 2, 3 and 1 (each within the scatter of the next, the first and the last beyond it).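

In this assay the chain on the nitrogen now has its first measured step, and a 1.7-fold higher number from compound 2 to compound 3 (0.22 log units; within the scatter) for isobutyl to propyl. At this place, on a saturated chain carbon bound to two saturated chain carbons, hydrogen can thus stand in place of methyl without a step beyond the usual scatter, at least on the shared core of compound 2 and compound 3. Nothing in the data shown bears on why the step stays this small.

Still open, on these data alone, is how the read-out responds to a shorter ethyl or a longer butyl chain on the nitrogen, or to a chain carrying a hydroxyl or an amine. Also open, as far as these compounds go, is whether isobutyl to propyl reads the same on the core of compound 1.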